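The source may hold more compounds than are shown below. What is called first, only, known or untested is meant among the compounds shown, and "the series" means these compounds.

Among the measured compounds shown here, compound 2 `Cc1ccc(-n2cc(CN3C(=O)C[C@@H]4CC[C@@]3(C)C4(C)C)nn2)cc1` gives 40 nM in a functional assay on OVCAR-3 cells (Homo sapiens) for inhibition, read by MTT assay, with a stated time of 24 h (a lower number here means a stronger inhibitor, a higher number a weaker inhibitor), the lowest number among the three measured members. Compound 1 `COc1ccc(-n2cc(CN3C(=O)C[C@@H]4CC[C@@]3(C)C4(C)C)nn2)cc1` gives 250 nM and compound 3 `CC1(C)[C@H]2CC[C@]1(C)N(Cc1cn(-c3cccc(F)c3)nn1)C(=O)C2` gives 430 nM; the steps of a 6.3-fold lower number from compound 1 to compound 2 (0.80 log units; beyond the scatter) and an 11-fold higher number from compound 2 to compound 3 (1.03 log units; beyond the scatter) both lie beyond the scatter, so compound 2 stands clearly apart from the other two. Compound 4 `COc1cccc(-n2cc(CN3C(=O)C[C@@H]4CC[C@@]3(C)C4(C)C)nn2)c1` is not yet measured; it differs from compound 2 by 3-methoxyphenyl in place of 4-methylphenyl on an aromatic nitrogen. For the measured compounds named here, two measured steps bear on this change. The step of a 6.3-fold lower number from compound 1 to compound 2 (0.80 log units; beyond the scatter) shows that the methoxy-bearing phenyl, there as 4-methoxyphenyl, gave the higher number. The step of an 11-fold higher number from compound 2 to compound 3 (1.03 log units; beyond the scatter) shows that exchanging 4-methylphenyl for 3-fluorophenyl raised the number by a large amount. Both point the same way: every departure from 4-methylphenyl seen so far has given a higher number, so for compound 4 a higher number is expected, a 7.5-fold higher number from compound 2 to compound 4 (0.88 log units; beyond the scatter), of modest to large size. Compound 4 is therefore estimated at 300 nM, with an expected range of 110 nM to 900 nM.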

Compound 4, half-maximal inhibitory concentration: 280 nM
The estimate for compound 4 lay 1.1-fold (0.03 log units) above the measured number, within the range that was stated.
By their numbers in this assay, from the lowest: compound 2; then compounds 1, 4 and 3 (each within the scatter of the next).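

In this assay, 3-methoxyphenyl on the aromatic nitrogen gives a 7.0-fold higher number from compound 2 to compound 4 (0.85 log units; beyond the scatter), so a methoxy-bearing phenyl gives the higher number with the methoxy in either of the two arrangements now shown. Those two arrangements cannot be told apart, with a 1.1-fold higher number from compound 1 to compound 4 (0.05 log units; within the scatter). Among the compounds shown here, the same holds for methoxy and fluoro on the 3-substituted phenyl, with a 1.5-fold lower number from compound 3 to compound 4 (0.19 log units; within the scatter), which leaves compound 2, the only methyl-bearing member, as the one compound standing apart from the other three.

No measurement accompanies these numbers that could account for the separation of compound 2. On these data alone, it remains open whether the low number belongs to the methyl group or to its placement, which 3-methylphenyl would address, and whether a longer chain, as in 4-ethylphenyl, or an amine such as 4-aminophenyl would keep it.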